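Methyl to fluoro on the pendant phenyl ring, second series

The source may report more compounds than this note shows. Statements on the series, on what has been measured and on what is new or still open speak of the compounds shown alone.

Compound 1 `COc1cc2c(Oc3ccc(NC(=O)c4cc(-c5ccc(C)cc5)ccn4)cc3F)ccnc2cc1OCCCN1CCCC1` was examined in a functional assay on MKN-45 cells (Homo sapiens) for cytotoxicity, read by MTT assay, with a stated time of 72 h (on this read-out lower numbers stand for stronger inhibition and higher numbers for weaker inhibition), where compound 1 gives 440 nM. Compound 2 `COc1cc2c(Oc3ccc(NC(=O)c4cc(-c5ccc(F)cc5)ccn4)cc3F)ccnc2cc1OCCCN1CCCC1` differs from it in one place: fluoro in place of methyl on an aromatic carbon. In this assay compound 2 gives 350 nM, which makes the step of a 1.3-fold lower number from compound 1 to compound 2 (0.10 log units; within the scatter).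

Compound 3 `COc1cc2c(Oc3ccc(NC(=O)c4nccc(-c5ccc(C)cc5)n4)cc3F)ccnc2cc1OCCCN1CCCCC1` carries a different core; the difference between the core of compound 1 and the core of compound 3 is not broken down here. In this assay compound 3 gives 580 nM, a number that sits within the scatter of both compound 1 and compound 2, so no order among the three can be read from these values.

Compound 4 `COc1cc2c(Oc3ccc(NC(=O)c4nccc(-c5ccc(F)cc5)n4)cc3F)ccnc2cc1OCCCN1CCCCC1` has not yet been measured. It differs from compound 3 in one place: fluoro in place of methyl on an aromatic carbon. The place of this change is described in the same words as the change from compound 1 to compound 2, so it is the same change made on a second core. For the measured compounds named here, the expected step for compound 4 is a 1.3-fold lower number from compound 3 to compound 4 (0.11 log units; within the scatter), and this expectation rests on the measured step of a 1.3-fold lower number from compound 1 to compound 2 (0.10 log units; within the scatter), which is the only occurrence of this change measured so far. On that basis compound 4 is expected to give about 450 nM in this assay, with an estimated range from 220 nM to 900 nM.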

Compound 4, half-maximal inhibitory concentration: 930 nM
Beside the measured number, compound 4's estimate is 2.1-fold (0.32 log units) below it; the measured number lies above the stated range.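

In this assay, putting 4-fluorophenyl in place of 4-methylphenyl on the core of compound 3 gives a 1.6-fold higher number from compound 3 to compound 4 (0.21 log units; within the scatter), and this step stands beside a 1.3-fold lower number from compound 1 to compound 2 (0.10 log units; within the scatter) on the core of compound 1. Set side by side, the two steps do not differ by more than two such steps would be expected to scatter: the same change on two cores in this assay, a 1.3-fold lower number (0.10 log units; within the scatter) from compound 1 to compound 2 and a 1.6-fold higher number (0.21 log units; within the scatter) from compound 3 to compound 4, 2.0-fold (0.30 log units) apart, within the scatter of two such steps. This shows that the swap leaves the number within the scatter on both cores and gives no sign that the core decides its outcome, so the opposite signs of the two steps cannot be read as a reversal; it does not show that the change carries over unaltered, as each core offers a single small step and a modest dependence on the core could stay hidden in the scatter.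

The compounds shown leave open whether a group with a larger effect at this place on the pendant phenyl ring, such as chloro, trifluoromethyl, nitrile or an amine, would give steps beyond the scatter on either core. They also leave open whether such steps would then match from one core to the other, which is the comparison that could actually test transfer in this series.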